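Substituents on the ring amide nitrogen: compound 4

The source may report more compounds than this note shows. Statements on the series, on what has been measured and on what is new or still open speak of the compounds shown alone.

The shared core is that of compound 1 `COc1cc(-c2nc3cc(/C=C4\SC(=O)NC4=O)ccc3[nH]2)cc(OC)c1OC`, which in a functional assay on HeLa cells (Homo sapiens) for inhibition, read by MTT assay, with a stated time of 48 h (on this read-out lower numbers stand for stronger inhibition and higher numbers for weaker inhibition), gives 1670 nM. Compound 2 `COc1cc(-c2nc3cc(/C=C4\SC(=O)N(CC(=O)N5CCOCC5)C4=O)ccc3[nH]2)cc(OC)c1OC` gives 16300 nM, and compound 3 `COc1cc(-c2nc3cc(/C=C4\SC(=O)N(CC(=O)N5CCCC5)C4=O)ccc3[nH]2)cc(OC)c1OC` gives 4780 nM. Both groups placed on the amide-type nitrogen in the ring weaken inhibition: a 9.8-fold higher number from compound 1 to compound 2 (0.99 log units; beyond the scatter) and a 2.9-fold higher number from compound 1 to compound 3 (0.46 log units; beyond the scatter); between the two substituted compounds, a 3.4-fold lower number from compound 2 to compound 3 (0.53 log units; beyond the scatter). Compound 3 thus stands second highest of the three numbers, nearer to compound 1 than to compound 2.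

Compound 4 `COc1cc(-c2nc3cc(/C=C4\SC(=O)N(Cc5cccc(C)c5)C4=O)ccc3[nH]2)cc(OC)c1OC` differs from compound 3 by 3-methylphenyl in place of (pyrrolidin-1-yl)carbonyl on a saturated chain carbon bound to an amide-type nitrogen in a ring. Within the data shown here, no measured step covers this exchange; the measured steps only show that each group tried on the ring nitrogen in place of hydrogen raised the number, modestly for compound 3 and more strongly for compound 2, and that the ring carried on the carbonyl made a modest difference. With nothing to separate 3-methylphenyl from those groups, the expected step, a 1.4-fold lower number from compound 3 to compound 4 (0.14 log units; within the scatter), is small, with a wide margin either way. Compound 4 is therefore estimated at 3500 nM, within 1000 nM to 12000 nM.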

Compound 4, half-maximal inhibitory concentration: 1440 nM
Estimate against measurement, compound 4: 2.4-fold (0.39 log units) above; the measured number falls inside the stated range.
By their numbers in this assay, from the lowest: compounds 4 and 1 (each within the scatter of the next); then compound 3; then compound 2.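

In this assay the amide hydrogen can be replaced without a loss beyond the scatter, as 3-methylbenzyl gives a 1.2-fold lower number from compound 1 to compound 4 (0.06 log units; within the scatter) and so departs from the rise seen with the other two groups on this nitrogen. The change of substituent also matters more than the earlier exchange of rings on the carbonyl: 3-methylphenyl in place of (pyrrolidin-1-yl)carbonyl gives a 3.3-fold lower number from compound 3 to compound 4 (0.52 log units; beyond the scatter) and in place of (morpholin-4-yl)carbonyl gives an 11-fold lower number from compound 2 to compound 4 (1.05 log units; beyond the scatter) on the same saturated chain carbon. Nothing measured here bears on why the groups on this nitrogen differ.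

Whether the methyl group contributes to the value of compound 4 remains open, as plain benzyl does not appear among these compounds. Going by these compounds, how a longer chain ending in an amine or a carboxylic acid would read at this nitrogen also remains open.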